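Series notes: amidine-bearing cores, step to cyclohexyl amine

The source may hold more compounds than are shown below. What is called first, only, known or untested is meant among the compounds shown, and "the series" means these compounds.

Values in a functional assay on PC-3 cells (Homo sapiens) for cytotoxicity, read by MTT assay, with a stated time of 72 h; a lower number here means a stronger inhibitor, a higher number a weaker inhibitor:
compound 1 `Cn1nc(-c2ccccc2)c2cc(C(=N)Nc3ccccc3)ncc21` gives 17300 nM
compound 2 `COc1ccc(Cn2nc(-c3ccccc3)c3cc(C(=N)Nc4ccc(N5CCN(C)CC5)cc4)nc(Nc4cc(OC)c(OC)c(OC)c4)c32)cc1` gives 1240 nM
compound 3 `N=C(Nc1ccccc1)c1cc2cn[nH]c2cn1` gives "not determined" (no result reported)

Compound 2 carries the lowest of the two numbers reported in this assay; its nearest neighbour is compound 1, whose value is higher by a margin beyond the usual scatter. Compound 3 adds no number to this comparison. Going by the values given here, no pair of measured compounds differs in a single place, so no measured step is available to guide the next change.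

Compound 4 `COc1ccc(Cn2nc(-c3ccccc3)c3cc(C(=N)Nc4ccc(N5CCN(C)CC5)cc4)nc(NC4CCCCC4)c32)cc1` is the unmeasured analogue of compound 2, with cyclohexyl in place of 3,4,5-trimethoxyphenyl on a nitrogen on an aromatic ring. Nothing in the measured set speaks to this exchange directly. Among the compounds with values here, with no comparable step on record, the expectation is a step of modest size, if any, and no direction is firmly indicated; a slight move toward a higher number is taken as the central case. The expected step from compound 2 to compound 4 in this assay is a 1.6-fold higher number from compound 2 to compound 4 (0.21 log units; within the scatter). For compound 4 the estimate in this assay is 2000 nM, with a range from 500 nM to 8000 nM.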

Compound 4, half-maximal inhibitory concentration: 3540 nM
Beside the measured number, compound 4's estimate is 1.8-fold (0.25 log units) below it, within the range that was stated.
By their numbers in this assay, from the lowest: compound 2; then compound 4; then compound 1.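

In this assay, going by these compounds alone, putting cyclohexyl in place of 3,4,5-trimethoxyphenyl on a nitrogen on an aromatic ring gives a 2.9-fold higher number from compound 2 to compound 4 (0.46 log units; beyond the scatter) and is the first single-place step on record for this series. The step shows that the group at this position affects the read-out, with the 3,4,5-trimethoxyphenyl compound holding the lower number of this pair. No supporting measurement is available to explain the size or direction of this step.

Within the data shown here, this exchange alters the ring type, the group size and the three methoxy groups together, so the single step cannot assign the change to any one of these features. A plain phenyl on the same nitrogen would separate the ring type from the methoxy groups, while a morpholine or a butyl chain would test other kinds of group at this position.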